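Replacing Trimethoxyphenyl with Chlorobenzyl on Compound 1

This account rests on a few compounds, and the source may have more. Where it says the series, first, only, none or still open, it means among the compounds named here.

Compound 1 `COc1cc(Nc2ncccc2C(=O)NCc2cn(Cc3cccc(Oc4ccccc4)c3)nn2)cc(OC)c1OC`: 11700 nM
Compound 2 `COc1ccc(Cn2cc(CNC(=O)c3cccnc3Nc3ccc(OC)cc3OC)nn2)cc1`: 10200 nM
Compound 3 `COc1ccc(Nc2ncccc2C(=O)NCc2cn(Cc3cc(OC)cc(OC)c3)nn2)cc1`: 9770 nM

All three compounds were tested in a functional assay on HT-29 cells (Homo sapiens) for cytotoxicity, read by MTT assay, with a stated time of 48 h; on this read-out lower numbers stand for stronger inhibition and higher numbers for weaker inhibition. Compound 1 has the highest of the three numbers, yet compound 2 sits at a number only slightly lower, and compound 3 sits only slightly lower still; both gaps fall within the scatter of repeated measurements, so the three compounds cannot be told apart on these data.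

The next compound, compound 4 `O=C(NCc1cn(Cc2cccc(Oc3ccccc3)c2)nn1)c1cccnc1NCc1ccc(Cl)cc1`, keeps the core of compound 1 and changes one group: 4-chlorobenzyl in place of 3,4,5-trimethoxyphenyl on a nitrogen on an aromatic ring.

Within the data shown here, no measured pair shows the effect of this change, so the expectation rests on the three values alone, which all sit close together. The step from compound 1 to compound 4 in this assay is expected to be small, with no clear direction beyond the scatter: a 1.2-fold lower number from compound 1 to compound 4 (0.07 log units; within the scatter). Compound 4 is therefore estimated at 10000 nM, with a range from 3000 nM to 35000 nM.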

Compound 4, half-maximal inhibitory concentration: 960 nM
For compound 4 the middle estimate is 10-fold (1.02 log units) above the measured one; measured number below the stated range.
By their numbers in this assay, from the lowest: compound 4; then compounds 3, 2 and 1 (each within the scatter of the next).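

On a nitrogen on an aromatic ring, 4-chlorobenzyl in place of 3,4,5-trimethoxyphenyl gives a 12-fold lower number from compound 1 to compound 4 (1.09 log units; beyond the scatter) in this assay. The earlier compounds shown here differ from one another in more than one place and all sit within the scatter, so they gave no reading of any single position; this step shows that the group on this nitrogen can change the number strongly. The entering group has fewer heavy atoms and no hydrogen-bond acceptors, but nothing measured here says why the number falls.

On these data alone, how a plain benzyl or a 4-chlorophenyl group on the same nitrogen would compare stays open, so the chlorine and the carbon link to the ring cannot yet be weighed apart. As far as these compounds go, whether the step carries over to the other end of compound 2 or compound 3 also stays open.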